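Extending the sulfonyl aryl group of a weak quinazoline series

The source may report more compounds than this note shows. Statements on the series, on what has been measured and on what is new or still open speak of the compounds shown alone.

The measured compounds and their values:
Compound 1, `COc1cc2nc(N3CCN(S(=O)(=O)c4ccc(C)cc4)CC3)nc(N)c2cc1OC`, gives 30000 nM.
Compound 2, `COc1ccc(S(=O)(=O)N2CCN(c3nc(N)c4cc(OC)c(OC)cc4n3)CC2)cc1`, gives 39000 nM.
Compound 3, `COc1cc2nc(N3CCN(S(=O)(=O)c4ccc(N)cc4N)CC3)nc(N)c2cc1OC`, gives 67000 nM.

All three were tested in a functional assay on PC-3 cells (Homo sapiens) for inhibition (a higher number here means a weaker inhibitor, a lower number a stronger inhibitor), and all three are weak. Compound 2 stands second highest of the three numbers; its nearest neighbour is compound 1, and its furthest is compound 3, yet both of those gaps lie within the scatter, so the three compounds cannot be told apart with confidence.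

Compound 4, `COc1cc2nc(N3CCN(S(=O)(=O)c4ccc(-c5ccc(C(F)(F)F)cc5)cc4)CC3)nc(N)c2cc1OC`, has not been measured. It differs from compound 2 in one place: 4-(trifluoromethyl)phenyl in place of methoxy on an aromatic carbon.

The measured steps touch only small groups on that aromatic carbon. The step of a 1.3-fold higher number from compound 1 to compound 2 (0.11 log units; within the scatter) is within the scatter, and a 2.2-fold higher number from compound 1 to compound 3 (0.35 log units; beyond the scatter) is modest, as is a 1.7-fold higher number from compound 2 to compound 3 (0.24 log units; within the scatter). Within the data shown here, none of them replaces a small group with a second aromatic ring, so no measured step bears directly on this change, and the direction is open. The expectation is therefore a step of uncertain direction, a 2.0-fold lower number from compound 2 to compound 4 (0.29 log units; within the scatter), with a wide range. Compound 4 is estimated at 20000 nM, between 4000 nM and 100000 nM.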

Compound 4, half-maximal inhibitory concentration: 3300 nM
Estimate against measurement, compound 4: 6.1-fold (0.78 log units) above, outside the stated range (below it).
By their numbers in this assay, from the lowest: compound 4; then compounds 1, 2 and 3 (each within the scatter of the next, the first and the last beyond it).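

In this assay, among these compounds, putting a second aromatic ring on this carbon gives a clear change for the first time: a 12-fold lower number from compound 2 to compound 4 (1.07 log units; beyond the scatter) when it replaces methoxy, and a 9.1-fold lower number from compound 1 to compound 4 (0.96 log units; beyond the scatter) when it replaces methyl. Among the earlier compounds, swapping the small groups methyl and methoxy at this position did little, with a 1.3-fold higher number from compound 1 to compound 2 (0.11 log units; within the scatter), so the position had given no sign that it could shift the result; the much larger 4-(trifluoromethyl)phenyl group now shows that it can, and in the direction of a stronger inhibitor. The data shown include no separate measurement that could explain why this larger group goes with a lower number.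

The change adds a ring and a trifluoromethyl group together, so the compounds shown leave open how much of the step belongs to each, a question that a plain phenyl ring on the same carbon would help to settle. Also open, going by these compounds, is how the number would respond if the outer ring carried an amine or a carboxylic acid in place of trifluoromethyl, or if a longer chain stood on this carbon instead of a ring.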